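Replacing methoxyphenyl with chlorophenyl on the shared core

This account rests on a few compounds, and the source may have more. Where it says the series, first, only, none or still open, it means among the compounds named here.

Compound 3 `COc1ccc(Nc2nc(SCc3cn(Cc4ccccc4Cl)nn3)nc(-c3ccccc3)c2C#N)cc1` gives 7560 nM in a functional assay on MGC-803 cells (Homo sapiens) for inhibition, read by MTT assay, with a stated time of 72 h (a higher number here means a weaker inhibitor, a lower number a stronger inhibitor), the lowest of the two numbers shown; compound 1 `C#CCSc1nc(Nc2ccc(OC)cc2)c(C#N)c(-c2ccccc2)n1` gives 28400 nM. Compound 2 `C#CCSc1nc(Nc2ccc(Cl)cc2)c(C#N)c(-c2ccccc2)n1` reaches only the assay limit of > 128000 nM. Compound 4 `N#Cc1c(Nc2ccccc2Cl)nc(SCc2cn(Cc3ccccc3Cl)nn2)nc1-c1ccccc1` differs from compound 3 by 2-chlorophenyl in place of 4-methoxyphenyl on a nitrogen on an aromatic ring. Going by the values given here, one measured step bears on this change: an at least 4.5-fold higher number from compound 1 to compound 2 (0.65 log units; beyond the scatter), a step whose size is known only as a lower bound, since one end rests on (the limit of > 128000 nM in this assay, at which 1 of the 3 values shown sits). Both changes remove a methoxy and bring in a chlorine on the ring attached to that nitrogen, so because an at least 4.5-fold higher number from compound 1 to compound 2 (0.65 log units; beyond the scatter) was at least modest, the step of a 5.3-fold higher number from compound 3 to compound 4 (0.72 log units; beyond the scatter) is expected to weaken inhibition. Compound 4 is therefore estimated at 40000 nM, between 12000 nM and 130000 nM.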

Compound 4, half-maximal inhibitory concentration: 4640 nM
For compound 4 the middle estimate is 8.6-fold (0.94 log units) above the measured one; measured number outside the range, below it.
By their numbers in this assay, from the lowest: compounds 4 and 3 (each within the scatter of the next); then compound 1. At a limit, above all of these: compound 2.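

In this assay, 2-chlorophenyl in place of 4-methoxyphenyl on a nitrogen on an aromatic ring gives a 1.6-fold lower number from compound 3 to compound 4 (0.21 log units; within the scatter), so the methoxy group is not needed at this position when the shared core carries the substituted triazole side chain of compound 3. The earlier step, an at least 4.5-fold higher number from compound 1 to compound 2 (0.65 log units; beyond the scatter), does not recur in this pair. For compound 2 the value is a limit: the limit of > 128000 nM in this assay, at which 1 of the 4 values shown sits.

The compounds shown do not settle whether the place of the chlorine on the ring or the other side chain accounts for the difference between the two steps. Going by these compounds, how an amine or a carboxylic acid on that ring would behave also stays open.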